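This account rests on a few compounds, and the source may have more. Where it says the series, first, only, none or still open, it means among the compounds named here.

Series notes, an in vitro ADME assay on microsomes from liver (Homo sapiens) for metabolic stability; on this read-out higher numbers stand for fast clearance and lower numbers for slow clearance

- Compound 1 `CC(C)C(=O)N(Cc1ccccc1C(F)(F)F)[C@H]1CCNC1`: < 7 mL.min-1.g-1, a limit of the assay.
- Compound 2 `CCOC(=O)N(Cc1ccccc1Oc1ccccc1)[C@H]1CCNC1`: 21 mL.min-1.g-1.
- Compound 3 `CC(=O)N(Cc1ccccc1-c1ccccc1)[C@H]1CCNC1`: < 7 mL.min-1.g-1, a limit of the assay.

Compound 3 stands at the limit of < 7 mL.min-1.g-1 in this assay, at which 2 of the 3 values shown sit. Its value is a limit, not a number. Compound 2 alone reports a number in this assay. The open compound 4 `CC(C)CC(=O)N(Cc1ccccc1-c1ccccc1)[C@H]1CCNC1` differs from compound 3 by isopropyl in place of hydrogen on a saturated chain carbon bound to a carbonyl carbon. For the measured compounds named here, no measured pair in the set carries this change, so the size of its effect is unknown here. The expectation for compound 4 in this assay is 12 mL.min-1.g-1, between 5 mL.min-1.g-1 and 30 mL.min-1.g-1. This amounts to an expected step of an at least 1.7-fold higher number from compound 3 to compound 4 (0.23 log units; that floor lies within the scatter), a small rise at most, with a fair chance that the result again comes back as a limit.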

Compound 4, intrinsic clearance in microsomes: 9 mL.min-1.g-1
Estimate against measurement, compound 4: 1.3-fold (0.12 log units) above; the range from low to high includes it.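

In this assay, isopropyl in place of hydrogen on a saturated chain carbon bound to a carbonyl carbon gives an at least 1.2-fold higher number from compound 3 to compound 4 (0.10 log units; that floor lies within the scatter). This position therefore takes the larger chain with no rise shown beyond the scatter, though the true size of the step stays unfixed. The step reads only as a floor because compound 3 carries a limit: the limit of < 7 mL.min-1.g-1 in this assay, at which 2 of the 4 values shown sit.

Open, going by these compounds, is how a longer chain, an amine or a carboxylic acid at this position would read in this assay.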